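Isobutoxy in place of methyl on the carbonyl carbon

The source may report more compounds than this note shows. Statements on the series, on what has been measured and on what is new or still open speak of the compounds shown alone.

Compound 1 `Cc1cc(C(=O)Nc2ccccn2)nn1Cc1cc(Cl)ccc1OCc1ccccc1`: in a physicochemical assay for lipophilicity, at pH 7.4 (a lower number here means a more polar compound, a higher number a more lipophilic compound), compound 1 gives > 3.7, a limit of the assay rather than a number.
Compound 2 `Cc1cc(C(N)=O)nn1Cc1cc(Cl)ccc1OCC(C)C`: in this assay compound 2 gives 3.1.
Compound 3 `CC(=O)Nc1cc(C)n(Cc2cc(Cl)ccc2OCc2ccccc2)n1`: in this assay compound 3 gives > 3.7, again a limit of the assay.

Compound 3 thus sits at the limit of this assay, where one further value shown also sits; only compound 2 yields a number. Among the measured compounds shown here, the one step between measured compounds that changes a single site, a step that the two limits leave unreadable from compound 1 to compound 3, runs between two limits and has no readable size. Compound 4 `Cc1cc(NC(=O)OCC(C)C)nn1Cc1cc(Cl)ccc1OCc1ccccc1` differs from compound 3 in one place: isobutoxy in place of methyl on a carbonyl carbon. Cut one bond further out, this reads acetamido to (isobutoxycarbonyl)amino. For the measured compounds named here, no measured step reads on this change; what is known is the limit of > 3.7 in this assay, at which 2 of the 3 values shown sit, and compound 3 already stands there. With compound 3 at the limit, an upward change would stay unreadable and only a marked downward step would return a number. Compound 4 is expected to remain at or past that limit, with an estimate of 4.5 (range 3.8 to 5.3). The step from compound 3 to compound 4 is accordingly estimated as a step that the limit leaves unreadable from compound 3 to compound 4, counted from the limit.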

Compound 4, distribution coefficient: 3.3
The estimate for compound 4 lay 1.20 log units above the measured number; measured number below the stated range.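

In this assay, isobutoxy in place of methyl on the carbonyl carbon gives a number at least 0.40 log units lower from compound 3 to compound 4 (beyond the scatter), so the larger group at this position does not keep the compound at the limit. (Isobutoxycarbonyl)amino in place of (pyridin-2-yl)carbamoyl on the aromatic carbon likewise gives a number at least 0.40 log units lower from compound 1 to compound 4 (beyond the scatter). Compound 4 thus supplies a number at this position, where the earlier step between two limits cannot be read, but the full size of both new steps stays open, since each starts from a limit: the limit of > 3.7 in this assay, at which 2 of the 4 values shown sit.

The compounds shown leave open whether the drop follows from the oxygen of the isobutoxy group or from the chain as a whole; a methoxy group or a plain isobutyl chain on the same carbonyl carbon would separate the two. Where an amine or a carboxylic acid at this position would stand in this assay also remains open.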